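Methyl for Fluoro on a Low-Toxicity Scaffold

The source may report more compounds than this note shows. Statements on the series, on what has been measured and on what is new or still open speak of the compounds shown alone.

Measured so far:
compound 1 `COC(=O)N[C@H](C(=O)N1C[C@@H](C)C[C@H]1c1ncc(-c2ccc(-c3ccc(-c4cc5[nH]c([C@@H]6C[C@H](C)CN6C(=O)[C@@H](NC(=O)OC)C(C)C)nc5s4)cc3)s2)[nH]1)C(C)C`: 18300 nM
compound 2 `COC(=O)N[C@H](C(=O)N1C[C@@H](C)C[C@H]1c1ncc(-c2ccc(-c3ccc(-c4cc5[nH]c([C@@H]6C[C@H](C)CN6C(=O)[C@@H](NC(=O)OC)C(C)C)nc5s4)cc3)cc2F)[nH]1)C(C)C`: > 20000 nM

In an ADME assay on HuhET cells (Homo sapiens) for cytotoxicity, read by thymidine incorporation (on this read-out higher numbers stand for lower toxicity in this test and lower numbers for higher toxicity in this test), compound 1 gives 18300 nM. Compound 2 sits at the limit of this assay, recorded as > 20000 nM, so only a range is known for it (the limit of > 20000 nM in this assay, at which 1 of the 2 values shown sits). Compound 3 `COC(=O)N[C@H](C(=O)N1C[C@@H](C)C[C@H]1c1ncc(-c2ccc(-c3ccc(-c4cc5[nH]c([C@@H]6C[C@H](C)CN6C(=O)[C@@H](NC(=O)OC)C(C)C)nc5s4)cc3)cc2C)[nH]1)C(C)C` differs from compound 2 by methyl in place of fluoro on an aromatic carbon. Among the compounds with values here, no measured pair shows this change, so the expected step of a number no higher from compound 2 to compound 3 (the limit leaves the size open) is none beyond the scatter. Compound 3 is therefore estimated at 20000 nM, within 10000 nM to 40000 nM, and is expected most likely to come back again as a limit rather than a number.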

Compound 3, half-maximal cytotoxic concentration: > 20000 nM
Compound 3 was reported as a limit; the forecaster's own chance of this, stated with the estimate: 65%; the middle value lies on the limit itself.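

Compound 2 and compound 3 are both reported only as limits, so no step can be read for methyl in place of fluoro: the limit of > 20000 nM in this assay, at which 2 of the 3 values shown sit.

The compounds shown leave open whether this change alters the result in this assay at all, since neither true value is known.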